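A nitro group in place of methoxy

The source may hold more compounds than are shown below. What is called first, only, known or untested is meant among the compounds shown, and "the series" means these compounds.

Compound 1 `O=C(Nc1ccc(C(=O)NO)cc1)Nc1ccc([N+](=O)[O-])cc1`: 12700 nM
Compound 2 `O=C(/C=C/c1ccc(NC(=O)Nc2ccccc2)cc1)NO`: 160 nM
Compound 3 `COc1ccc(NC(=O)Nc2ccc(/C=C/C(=O)NO)cc2)cc1`: 110 nM
Compound 4 `O=C(/C=C/c1ccc(NC(=O)Nc2ccc([N+](=O)[O-])cc2)cc1)NO`: not yet measured

In a functional assay on Jurkat cells (Homo sapiens) for cytotoxicity, read by MTT assay, with a stated time of 72 h (on this read-out higher numbers stand for weaker inhibition and lower numbers for stronger inhibition), compound 3 gives 110 nM. That value lies within the scatter of compound 2, and compound 1 has a much higher number. Compound 4 carries nitro in place of methoxy on an aromatic carbon, para to a large group: nitro in place of methoxy on an aromatic carbon. Among the compounds with values here, one measured step concerns a change at an aromatic carbon, methoxy in place of hydrogen, and it is small: a 1.5-fold lower number from compound 2 to compound 3 (0.16 log units; within the scatter). Within the data shown here, the core of compound 4 differs from that of compound 1, which also carries a nitro group, so compound 1 with its value of 12700 nM offers no measured step for this change. On this evidence, no step beyond the scatter is expected in this assay, with at most a slight rise in the number. The expected change is a 1.8-fold higher number from compound 3 to compound 4 (0.26 log units; within the scatter). For compound 4 the estimated value is 200 nM, with an expected range from 70 nM to 600 nM.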

Compound 4, half-maximal inhibitory concentration: 90 nM
Compound 4: the middle estimate sits 2.2-fold (0.35 log units) above what was measured, within the range that was stated.
By their numbers in this assay, from the lowest: compounds 4, 3 and 2 (each within the scatter of the next); then compound 1.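

In this assay, hydrogen, methoxy and nitro on this aromatic carbon, para to a large group, give numbers within the scatter of each other (a 1.2-fold lower number from compound 3 to compound 4 (0.09 log units; within the scatter); a 1.8-fold lower number from compound 2 to compound 4 (0.25 log units; within the scatter)). With nitro now held constant, the very high number of compound 1 can be set against a single difference at the other end of the molecule, 2-(hydroxycarbamoyl)ethenyl in place of hydroxycarbamoyl (a 140-fold lower number from compound 1 to compound 4 (2.15 log units; beyond the scatter)). No measurement is available to explain either result.

Going by these compounds, whether an amine or a carboxylic acid on this aromatic carbon would also stay within the scatter remains open. So does how a longer chain carrying the hydroxycarbamoyl group would compare with 2-(hydroxycarbamoyl)ethenyl.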